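The compounds below may be only part of what the source reports. "The series", "measured", "known", "first", "only" and "open" are said of these compounds alone.

Compound 1 `Nc1nnc(SC[C@H]2O[C@@H](OCc3noc(-c4ccc(Cl)cc4)n3)[C@@H]3OC4(CCCC4)O[C@@H]32)s1` carries a chlorine on its outer benzene ring and is, on the numbers shown, one of three compounds tested. In a functional assay on SW1573 cells (Homo sapiens) for antiproliferative activity, read by sulforhodamine B assay, with a stated time of 48 h (on this read-out lower numbers stand for stronger inhibition of growth and higher numbers for weaker inhibition of growth), compound 1 gives 17000 nM, which is the lowest of the two numbers that are numbers at all. Compound 2 `CC(=O)OC[C@H]1O[C@@H](OCc2noc(-c3ccc([N+](=O)[O-])cc3)n2)[C@@H]2OC3(CCCC3)O[C@@H]21`, which has an acetate in place of the aminothiadiazole thioether and a nitro group on the outer ring, gives 29000 nM in this assay, and that sits within the scatter of the value of compound 1. Compound 3 `CC1(C)O[C@H]2[C@H](OCc3noc(-c4ccc([N+](=O)[O-])cc4)n3)O[C@H](CSc3nnc(N)s3)[C@H]2O1`, with the smaller acetal and the nitro group, gives > 100000 nM in this assay, which is a limit of the assay and not a number, namely (the limit of > 100000 nM in this assay, at which 1 of the 3 values shown sits), so no number is known for it. Compound 4 `Nc1nnc(SC[C@H]2O[C@@H](OCc3noc(-c4ccc([N+](=O)[O-])cc4)n3)[C@@H]3OC4(CCCC4)O[C@@H]32)s1` has not yet been measured. It differs from compound 1 in one place: nitro in place of chloro on an aromatic carbon. Since the two nitro-bearing compounds shown are no better than compound 1, the step in this assay is expected to be small or slightly toward weaker inhibition, as a 1.8-fold higher number from compound 1 to compound 4 (0.25 log units; within the scatter). Compound 4 is estimated at 30000 nM, within 10000 nM to 100000 nM.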

Compound 4, concentration for 50% growth inhibition: 16000 nM
Estimate against measurement, compound 4: 1.9-fold (0.27 log units) above; the measured number falls inside the stated range.
By their numbers in this assay, from the lowest: compounds 4, 1 and 2 (each within the scatter of the next). At a limit, above all of these: compound 3.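

With nitro in place of chloro on the outer benzene ring, para to a large group, this assay shows a 1.1-fold lower number from compound 1 to compound 4 (0.03 log units; within the scatter), so the two groups cannot be told apart at this position. With the nitro group held fixed, (5-amino-1,3,4-thiadiazol-2-yl)sulfanyl in place of acetoxy gives a 1.8-fold lower number from compound 2 to compound 4 (0.26 log units; within the scatter), so these two groups cannot be told apart on the nitro-bearing compounds either. Compound 3, which shares the nitro group and the aminothiadiazole thioether of compound 4 but has the smaller acetal, stands at a limit of the assay and not at a number: the limit of > 100000 nM in this assay, at which 1 of the 4 values shown sits.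

As far as these compounds go, whether an amine, a methoxy group or a carboxylic acid at this position would give a value beyond the scatter remains open. Also open, from the compounds shown here alone, is how the core of compound 4 behaves with a plain hydrogen in place of the nitro group.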